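A second hydroxy on compound 3

This account rests on a few compounds, and the source may have more. Where it says the series, first, only, none or still open, it means among the compounds named here.

Compound 1 (`COc1ccc(/C=C2\CCC/C(=C\c3cccc(Cl)c3)C2=O)cc1OC`) gives 6000 nM
Compound 2 (`COc1ccc(/C=C2\CCC/C(=C\c3cccc(Br)c3)C2=O)cc1OC`) gives 5300 nM
Compound 3 (`COc1ccc(/C=C2\CCC/C(=C\c3cccc(O)c3)C2=O)cc1OC`) gives 2900 nM

All three values come from a functional assay on MCF7 cells (Homo sapiens) for cytotoxicity, read by MTT assay, with a stated time of 72 h (on this read-out lower numbers stand for stronger inhibition and higher numbers for weaker inhibition), and the compounds differ in a single group. Trading chloro for bromo changes little, with a 1.1-fold lower number from compound 1 to compound 2 (0.05 log units; within the scatter) as the result. Compound 3 stands clear of compound 1 but remains within the scatter of compound 2.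

Compound 4 (`COc1ccc(/C=C2\CCC/C(=C\c3ccc(O)c(O)c3)C2=O)cc1OC`) adds hydroxy in place of hydrogen on an aromatic carbon, ortho to a hydroxy group and para to a large group (hydroxy in place of hydrogen on an aromatic carbon). This turns 3-hydroxyphenyl into 3,4-dihydroxyphenyl. Among the compounds with values here, no measured step makes this exact change. With only a 2.1-fold lower number from compound 1 to compound 3 (0.32 log units; beyond the scatter) and a 1.8-fold lower number from compound 2 to compound 3 (0.26 log units; within the scatter) as the nearest evidence, each putting hydroxy in place of a halogen, a small step toward a lower number is expected in this assay, perhaps none beyond the scatter. The estimated change is a 1.5-fold lower number from compound 3 to compound 4 (0.16 log units; within the scatter) and remains uncertain. For compound 4 the estimated value is 2000 nM, with an expected range from 700 nM to 5500 nM.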

Compound 4, half-maximal inhibitory concentration: 14400 nM
Beside the measured number, compound 4's estimate is 7.2-fold (0.86 log units) below it; the measured number lies above the stated range.
By their numbers in this assay, from the lowest: compounds 3, 2 and 1 (each within the scatter of the next, the first and the last beyond it); then compound 4.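

In this assay the added hydroxy costs activity, with a 5.0-fold higher number from compound 3 to compound 4 (0.70 log units; beyond the scatter) as the step, so the lower number that came with hydroxy in place of chloro does not carry over to a further hydroxy on the same ring. The change even takes this ring past both halogen compounds, with a 2.7-fold higher number from compound 2 to compound 4 (0.43 log units; beyond the scatter) and a 2.4-fold higher number from compound 1 to compound 4 (0.38 log units; beyond the scatter) as the steps, which makes compound 4 the weakest of the four. No measurement shown accounts for this reversal.

The compounds shown leave open whether the higher number follows the new hydroxy on its own or the two hydroxy groups together. They also leave open whether an amine or a carboxylic acid in the same place would raise the number as well.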